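The compounds below may be only part of what the source reports. "The series", "measured", "known", "first", "only" and "open" are said of these compounds alone.

Compound 1 `Nc1scc(-c2ccccc2)c1C(=O)c1ccccc1` is the starting point. In a functional assay on CHO cells for agonist activity at adenosine receptor A1 (Homo sapiens), read by fluorescence and ERK phosphorylation, with stated times of 30 min and 1.5 h, tested at 10 uM (on this read-out higher numbers stand for a stronger effect at the one concentration tested and lower numbers for a weaker effect), compound 1 gives 48%, which places it at the low end of the three numbers seen so far: compound 3 `Nc1scc(-c2ccc(Br)cc2)c1C(=O)c1ccccc1` gives 49%, a change that is a number 1 percentage points higher from compound 1 to compound 3 (within the scatter), while compound 2 `Nc1scc(-c2ccc(F)cc2)c1C(=O)c1ccccc1` gives 60%, a change that is a number 12 percentage points higher from compound 1 to compound 2 (beyond the scatter).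

Compound 4 `COc1cccc(-c2csc(N)c2C(=O)c2ccccc2)c1` differs from compound 1 in one way: methoxy in place of hydrogen on an aromatic carbon. The two measured steps that speak to this change are those in which a single substituent replaces a hydrogen on the same six-membered ring of carbon, from compound 1 to compound 2 and from compound 1 to compound 3. One of them was modest and one lay within the scatter, so a replacement of this kind appears to move the number only a little, if at all. Compound 4 is therefore expected to give 52%, within a range from 38% to 66%, which amounts to an expected step of a number 4 percentage points higher from compound 1 to compound 4 (within the scatter).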

Compound 4, a percentage reported as activity, at one concentration (the size of the read-out at that concentration, not a potency): 34%
Beside the measured number, compound 4's estimate is 18 percentage points above it, and the stated range ends above it.
By their numbers in this assay, from the lowest: compound 4; then compounds 1 and 3 (each within the scatter of the next); then compound 2.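

In this assay, methoxy on this ring, meta to a large group, gives a number 14 percentage points lower from compound 1 to compound 4 (beyond the scatter). Among the compounds shown here, the earlier replacements of hydrogen on this ring gave a number 12 percentage points higher from compound 1 to compound 2 (beyond the scatter) and a number 1 percentage points higher from compound 1 to compound 3 (within the scatter), so this is the first such step to go downward beyond the scatter, and a substituent on this ring can lower the number as well as raise it or leave it in place. Nothing measured here explains the drop.

With a single methoxy compound, the compounds shown cannot separate the effect of the group itself from the effect of where it sits on the ring. On these data alone, it also remains open whether a hydroxyl, an amine or a longer chain such as ethoxy at this same place would lower the number too.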